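Carbamoyl to Isopropylsulfanylcarbonyl: An Expected Binding Shift

A few compounds are considered here, and "the series" means these few. Any claim that something is new, unique, unknown or untested is made for them only; others in the source may bear on it.

Of the compounds shown here, three sharing one core have been tested in an assay on membranes from CHO cells for displacement of a labelled ligand from adenosine receptor A1 (Homo sapiens), read by scintillation counting, with a stated time of 60 min, tested at 1 uM; on this read-out lower numbers stand for less inhibition and higher numbers for more inhibition at the one concentration tested (going by the name of the read-out). Compound 1 `CC1=C(C(=O)OCc2ccccc2)C(c2ccco2)NC(=O)N1` gives 36%. Compound 2 `CC1=C(C(N)=O)C(c2ccoc2)NC(=O)N1` gives 1%, and compound 3 `CC1=C(C(N)=O)C(c2ccsc2)NC(=O)N1` gives 2%. Compound 3 thus stands second of the three, close to compound 2 and beyond the scatter beneath compound 1; the step of a number 1 percentage points higher from compound 2 to compound 3 (within the scatter) lies within the scatter. Compound 4 `CC1=C(C(=O)SC(C)C)C(c2ccsc2)NC(=O)N1` differs from compound 3 in one place: isopropylsulfanyl in place of amino on a carbonyl carbon. Among the measured compounds shown here, no measured step covers this change. For the measured compounds named here, the only hint is that compound 1, which lacks the carbamoyl group of compounds 2 and 3 and differs elsewhere too, shows the higher number. Compound 4 is expected to give 30%, within a range from 8% to 60%. This corresponds to an expected step of a number 28 percentage points higher from compound 3 to compound 4 (beyond the scatter).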

Compound 4, a percentage reported as inhibition, at one concentration (the size of the read-out at that concentration, not a potency): 24%
Compound 4: middle estimate off by 6 percentage points, on the high side, within the range that was stated.
By their numbers in this assay, from the lowest: compounds 2 and 3 (each within the scatter of the next); then compound 4; then compound 1.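

In this assay, among the compounds shown here, isopropylsulfanyl in place of amino on a carbonyl carbon gives a number 22 percentage points higher from compound 3 to compound 4 (beyond the scatter), the only measured step at this position with the rest of the structure unchanged. The read-out at this position therefore responds to this change, at least in this one pair. No measurement shown explains the rise.

The compounds shown do not separate the contribution of the sulfur from that of the isopropyl chain, and an isopropyl ester or a methylsulfanyl group on the same carbonyl carbon would address this. From the compounds shown here alone, whether the step carries over to the furan-3-yl compound also remains open.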